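Dihydroxyphenyl to dinitrophenyl: compound 3 to compound 4

The compounds below may be only part of what the source reports. "The series", "measured", "known", "first", "only" and "open" are said of these compounds alone.

Compound 1 `Cc1cc(C)cc(NC(=O)NCCNS(=O)(=O)c2ccc(-c3ccccc3Oc3ccc([N+](=O)[O-])c([N+](=O)[O-])c3)s2)c1`: 12000 nM
Compound 2 `O=C(NCCNS(=O)(=O)c1ccc(-c2ccccc2OCc2cccc(O)c2)s1)Nc1cc(Cl)cc(Cl)c1`: > 50000 nM, a limit
Compound 3 `O=C(NCCNS(=O)(=O)c1ccc(-c2ccccc2Oc2ccc(O)c(O)c2)s1)Nc1cc(Cl)cc(Cl)c1`: > 20000 nM, a limit

In a functional assay on HeLa cells (Homo sapiens) for inhibition, read by CCK-8 assay, with a stated time of 48 h (a lower number here means a stronger inhibitor, a higher number a weaker inhibitor), compound 3 has only a limit, > 20000 nM. Going by the values given here, the one measured step reaching it, a step that the two limits leave unreadable from compound 2 to compound 3, offers no size to carry forward. Compound 4 `O=C(NCCNS(=O)(=O)c1ccc(-c2ccccc2Oc2ccc([N+](=O)[O-])c([N+](=O)[O-])c2)s1)Nc1cc(Cl)cc(Cl)c1` carries this change: 3,4-dinitrophenyl in place of 3,4-dihydroxyphenyl on an oxygen on an aromatic ring. Among the compounds with values here, the only guide is compound 1, which has the same 3,4-dinitrophenyl group but differs from compound 4 elsewhere. On the value of compound 1, 12000 nM, the expected step is an at least 2.0-fold lower number from compound 3 to compound 4 (0.30 log units; that floor lies within the scatter), towards stronger inhibition in this assay. For compound 4 the estimate is 10000 nM, with an expected range of 3000 nM to 35000 nM.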

Compound 4, half-maximal inhibitory concentration: > 20000 nM
Compound 4 ended at the assay's limit (the forecaster's own chance of this, stated with the estimate: 25%); at least 2.0-fold (0.30 log units) between middle value and limit.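

In this assay, 3,4-dinitrophenyl in place of 3,4-dihydroxyphenyl on an oxygen on an aromatic ring brings no readable gain, and the steps that end in a limit at both compounds cannot be read. Compound 3 and compound 4 share one limit: the limit of > 20000 nM in this assay, at which 2 of the 4 values shown sit.

Going by these compounds alone, with 3,4-dinitrophenyl held, 3,5-dichlorophenyl in place of 3,5-dimethylphenyl on an amide-type nitrogen gives an at least 1.6-fold higher number from compound 1 to compound 4 (0.22 log units; that floor lies within the scatter), the only readable step here, with only its floor known.

Going by these compounds, whether an amine or a carboxylic acid on that aromatic ring in place of the nitro groups would give a measurable value with 3,5-dichlorophenyl stays open.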